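The source may report more compounds than this note shows. Statements on the series, on what has been measured and on what is new or still open speak of the compounds shown alone.

Compound 1 `O=C(Nc1ccccc1)Nc1nnc(Sc2ncnc3scc(-c4ccncc4)c23)s1` gives 5700 nM in a functional assay on PC-3 cells (Homo sapiens) for antiproliferative activity, read by MTT assay, with a stated time of 48 h; a higher number here means a weaker inhibitor, a lower number a stronger inhibitor. Compound 2 `Cc1ccc(NC(=O)Nc2nnc(Sc3ncnc4scc(-c5ccncc5)c34)s2)cc1Cl` gives 4700 nM in this assay. Compound 3 `O=C(Nc1ccc(Cl)c(C(F)(F)F)c1)Nc1nnc(Sc2ncnc3scc(-c4ccncc4)c23)s1` gives 12100 nM in this assay.

Among these three, compound 3 carries the highest number and so is the weakest inhibitor of the set: the steps of a 2.1-fold higher number from compound 1 to compound 3 (0.33 log units; beyond the scatter) and a 2.6-fold higher number from compound 2 to compound 3 (0.41 log units; beyond the scatter) both lie beyond the scatter, whereas the step of a 1.2-fold lower number from compound 1 to compound 2 (0.08 log units; within the scatter) stays within it, so compounds 1 and 2 cannot be told apart.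

Compound 4 `O=C(Nc1cccc(F)c1)Nc1nnc(Sc2ncnc3scc(-c4ccncc4)c23)s1` differs from compound 3 in one place: 3-fluorophenyl in place of 4-chloro-3-(trifluoromethyl)phenyl on an amide-type nitrogen. The two measured steps that bear on this are the ones leading into compound 3, which exchanged a plain or lightly substituted phenyl for the 4-chloro-3-(trifluoromethyl)phenyl and raised the number modestly each time. Compound 4 goes back toward a lightly substituted phenyl, so the expectation is that this modest rise is roughly undone. The step of a 2.0-fold lower number from compound 3 to compound 4 (0.30 log units; within the scatter) is therefore expected to be a modest one toward a lower number, landing near compounds 1 and 2. Compound 4 is expected to give about 6000 nM in this assay, with a range from 3000 nM to 12000 nM.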

Compound 4, half-maximal inhibitory concentration: 6600 nM
Compound 4: the middle estimate sits 1.1-fold (0.04 log units) below what was measured; low and high end bracket the measured number.
By their numbers in this assay, from the lowest: compounds 2, 1, 4 and 3 (each within the scatter of the next, the first and the last beyond it).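

Adding a single fluoro to the phenyl on the amide-type nitrogen of compound 1 (a 1.2-fold higher number from compound 1 to compound 4 (0.06 log units; within the scatter)) gives no readable change in this assay, so this position tolerates that small substitution in this assay. Compared with the 3-chloro-4-methylphenyl of compound 2, the 3-fluorophenyl also gives no readable difference (a 1.4-fold higher number from compound 2 to compound 4 (0.15 log units; within the scatter)). The exchange of the 4-chloro-3-(trifluoromethyl)phenyl for the 3-fluorophenyl (a 1.8-fold lower number from compound 3 to compound 4 (0.26 log units; within the scatter)) likewise stays within the scatter, so compound 3, though separated from compound 1 and compound 2, can no longer be called the weakest of the set, and no information is available here to explain these numbers.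

From the compounds shown here alone, all four compounds carry a phenyl ring on this nitrogen, bearing only hydrogen, halogen, methyl or trifluoromethyl substituents, so it remains open how this assay would respond to an amine or a carboxylic acid on that ring. Going by these compounds, it also remains open whether the ring itself is needed, or whether a cyclohexyl group or a longer alkyl chain could take its place.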